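The compounds below may be only part of what the source reports. "The series", "measured", "known", "first", "only" and "open" are said of these compounds alone.

Compound 2 `O=C1N=C(N2N=C(c3ccccc3)CC2c2ccc(Cl)cc2)S/C1=C1/C(=O)Nc2ccccc21`: 320 nM
Compound 1 `COc1ccc(C2CC(c3ccccc3)=NN2C2=NC(=O)/C(=C3\C(=O)Nc4ccccc43)S2)cc1`: 2020 nM

In a functional assay on cells (Cancer cell lines, Homo sapiens) for cytotoxicity, read by sulforhodamine B assay, with a stated time of 48 h (a lower number here means a stronger inhibitor of growth, a higher number a weaker inhibitor of growth), compound 2 gives 320 nM, the lowest of the two numbers measured. Compound 1 gives 2020 nM. For the measured compounds named here, the one measured step reads a 6.3-fold lower number from compound 1 to compound 2 (0.80 log units; beyond the scatter). Compound 3 `CN(C)c1ccc(C2CC(c3ccccc3)=NN2C2=NC(=O)/C(=C3\C(=O)Nc4ccccc43)S2)cc1` differs from compound 2 by dimethylamino in place of chloro on an aromatic carbon. That single step shows a swap of this group can move the result well beyond the scatter, but dimethylamino itself has not been measured here, so the direction rests on little. Compound 3 is expected to give 1000 nM, with a range from 300 nM to 4000 nM, an expected step of a 3.1-fold higher number from compound 2 to compound 3 (0.49 log units; beyond the scatter) toward a weaker inhibitor.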

Compound 3, concentration for 50% growth inhibition: 5260 nM
The estimate for compound 3 lay 5.3-fold (0.72 log units) below the measured number, and the stated range ends below it.
By their numbers in this assay, from the lowest: compound 2; then compound 1; then compound 3.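

Dimethylamino proves a poor replacement at this position: putting it in place of chloro gives a 16-fold higher number from compound 2 to compound 3 (1.22 log units; beyond the scatter) and is a large loss, so the third group widens the spread seen so far. Putting it in place of methoxy gives a 2.6-fold higher number from compound 1 to compound 3 (0.42 log units; beyond the scatter) as well, which places all three groups apart, with chloro best and dimethylamino worst. No measurement shown explains this order. Still open, going by these compounds, is whether bromo or fluoro in the same place would match chloro, and whether a primary amine would fare as poorly as dimethylamino.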